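Thiophene substituent change from hydroxymethyl to cyclopentyl

A few compounds are considered here, and "the series" means these few. Any claim that something is new, unique, unknown or untested is made for them only; others in the source may bear on it.

Measured compounds:
compound 1, `CC(C)=Cc1sc(C(C)C)c(/C=C/[C@@H](O)C[C@@H](O)CC(=O)O)c1-c1ccc(F)cc1`, 15 nM
compound 2, `CCCCCCCCc1sc(C(C)C)c(/C=C/[C@@H](O)C[C@@H](O)CC(=O)O)c1-c1ccc(F)cc1`, a limit of > 10000 nM
compound 3, `CC(C)c1sc(CO)c(-c2ccc(F)cc2)c1/C=C/[C@@H](O)C[C@@H](O)CC(=O)O`, 325 nM

Three compounds sharing one core were measured in an assay on microsomes for inhibition of 3-hydroxy-3-methylglutaryl-coenzyme A reductase (Rattus norvegicus); a lower number here means a stronger inhibitor, a higher number a weaker inhibitor. Compound 1 gives 15 nM. Compound 3 gives 325 nM and stands highest of the two numbers shown, with compound 1 the nearer of them. For compound 2 this assay reports only a limit, > 10000 nM, and no number.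

The measured steps are large. Going an at least 660-fold higher number from compound 1 to compound 2 (2.82 log units; beyond the scatter), while a 22-fold higher number from compound 1 to compound 3 (1.34 log units; beyond the scatter). In the other direction, an at least 30-fold lower number from compound 2 to compound 3 (1.48 log units; beyond the scatter).

Compound 4, `CC(C)c1sc(C2CCCC2)c(-c2ccc(F)cc2)c1/C=C/[C@@H](O)C[C@@H](O)CC(=O)O`, has not been measured. It differs from compound 3 in one place: cyclopentyl in place of hydroxymethyl on an aromatic carbon. The steps that bear on it are those from compound 1, where a group of similar size to cyclopentyl gives the lowest number shown, and the step to compound 2, where a long chain reaches the limit. Since cyclopentyl is compact rather than a long chain, the change is expected to lower the number substantially, toward compound 1. The expected step is an 11-fold lower number from compound 3 to compound 4 (1.03 log units; beyond the scatter). Compound 4 is therefore estimated at 30 nM, between 8 nM and 150 nM.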

Compound 4, half-maximal inhibitory concentration: 570 nM
Compound 4: the middle estimate sits 19-fold (1.28 log units) below what was measured, outside the stated range (above it).
By their numbers in this assay, from the lowest: compound 1; then compounds 3 and 4 (each within the scatter of the next). At a limit, above all of these: compound 2.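

Cyclopentyl and hydroxymethyl are not told apart at this position: a 1.8-fold higher number from compound 3 to compound 4 (0.24 log units; within the scatter), even though the entering ring has no hydrogen-bond donor or acceptor and the leaving group has one of each. A five-membered ring of carbon only also does not reproduce the result of the 2-methylprop-1-en-1-yl group, with a 38-fold higher number from compound 1 to compound 4 (1.58 log units; beyond the scatter), so the low number of compound 1 is not shared by every small carbon group placed on this aromatic carbon. Cyclopentyl nonetheless stays well clear of octyl, with an at least 17-fold lower number from compound 2 to compound 4 (1.24 log units; beyond the scatter), a step that rests on a limit rather than a number for compound 2: the limit of > 10000 nM in this assay, at which 1 of the 4 values shown sits.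

What the compounds shown leave open is whether the low number of compound 1 depends on its carbon-carbon double bond or on its branching, a question that a saturated 2-methylpropyl group at this place would address. Also open, as far as these compounds go, is how an amine, a carboxylic acid, a phenyl group or a chain of intermediate length, such as butyl, would behave here.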